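Adding a Nitro Group to the Aniline Ring of Compound 1

The source may report more compounds than this note shows. Statements on the series, on what has been measured and on what is new or still open speak of the compounds shown alone.

Measured compounds:
compound 1 `c1ccc(Cn2c(Nc3ccccc3)nc3ncccc32)cc1`: 52500 nM
compound 2 `Oc1ccc(Nc2nc3ncccc3n2Cc2ccccc2)cc1`: 52500 nM
compound 3 `Clc1cccc(Nc2nc3ncccc3n2Cc2ccccc2)c1`: 43500 nM

In a functional assay on MCF7 cells (Homo sapiens) for antiproliferative activity, read by MTT assay, with a stated time of 72 h (on this read-out lower numbers stand for stronger inhibition of growth and higher numbers for weaker inhibition of growth), compound 1 stands level with compound 2, and together they give the highest of the three numbers. Its nearest neighbour is compound 2, with no change at the digits printed from compound 1 to compound 2 (within the scatter); its furthest is compound 3, with a 1.2-fold lower number from compound 1 to compound 3 (0.08 log units; within the scatter). Compound 4 `O=[N+]([O-])c1cccc(Nc2nc3ncccc3n2Cc2ccccc2)c1` arises from compound 1 by nitro in place of hydrogen on an aromatic carbon. Among the compounds with values here, the steps that bear on this are those to compound 2 and compound 3, both substitutions on the same ring of compound 1, and both stayed within the scatter, as did a 1.2-fold lower number from compound 2 to compound 3 (0.08 log units; within the scatter). No step beyond the scatter is therefore expected in this assay, so compound 4 is estimated at 48000 nM, between 24000 nM and 96000 nM, which means an expected 1.1-fold lower number from compound 1 to compound 4 (0.04 log units; within the scatter).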

Compound 4, concentration for 50% growth inhibition: 24200 nM
The estimate for compound 4 lay 2.0-fold (0.30 log units) above the measured number; the range from low to high includes it.
By their numbers in this assay, from the lowest: compounds 4, 3, 1 and 2 (each within the scatter of the next, the first and the last beyond it).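

In this assay, within the data shown here, nitro on an aromatic carbon meta to a large group is the first change in this set to move the number beyond the scatter (a 2.2-fold lower number from compound 1 to compound 4 (0.34 log units; beyond the scatter)), though the step is modest. Nitro and chloro at this place cannot be told apart (a 1.8-fold lower number from compound 3 to compound 4 (0.25 log units; within the scatter)). Nothing available gives a reason for the step. As far as these compounds go, whether an amine or a carboxylic acid at this place would give a larger step remains open, as does the effect of nitro where compound 2 carries its hydroxy.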